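The compounds below may be only part of what the source reports. "The series", "measured", "known", "first", "only" and "open" are said of these compounds alone.

Compound 1 `O=C(c1ccc(CN2C(=O)c3ccccc3S2(=O)=O)cc1)N1CCCCC1` carries a piperidin-1-yl group on the carbonyl carbon attached to the aromatic ring. For the measured compounds named here, in an ADME assay on RAW264.7 cells (Mus musculus) for cytotoxicity, read by WST assay (on this read-out lower numbers stand for higher toxicity in this test and higher numbers for lower toxicity in this test), compound 1 gives 69200 nM, the only plain number among the two values recorded for this series. Compound 2 `O=C(c1ccc(Cn2sc3ccccc3c2=O)cc1)N1CCCCC1` sits at a limit of the test: in this assay compound 2 gives > 100000 nM, which is a limit and not a number. Going by the values given here, compound 1 therefore stands as the single measured number, with the other value resting at the limit of > 100000 nM in this assay, at which 1 of the 2 values shown sits. Among the compounds with values here, no step between two measured compounds is available here, since compound 1 and compound 2 share the same piperidin-1-yl amide and differ elsewhere, so the two values show only that both lie at weak toxicity. Compound 3 `CC(C)(C)OC(=O)NC(=O)c1ccc(CN2C(=O)c3ccccc3S2(=O)=O)cc1` differs from compound 1 by (tert-butoxycarbonyl)amino in place of piperidin-1-yl on a carbonyl carbon. For compound 3 the step from compound 1 is expected to be small, a 1.2-fold higher number from compound 1 to compound 3 (0.06 log units; within the scatter), in no firm direction beyond the usual scatter. Compound 3 is thus estimated at 80000 nM in this assay, within a range from 30000 nM to 200000 nM, with a fair chance that the test reports only a limit.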

Compound 3, concentration lethal to 50% of the cells: > 100000 nM
Compound 3 ended at the assay's limit (the forecaster's own chance of this, stated with the estimate: 45%); at least 1.2-fold (0.09 log units) between middle value and limit.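

this assay gives the first readable step at this position: putting (tert-butoxycarbonyl)amino in place of piperidin-1-yl on a carbonyl carbon, with the core of compound 1 kept, gives an at least 1.4-fold higher number from compound 1 to compound 3 (0.15 log units; that floor lies within the scatter). The change takes away a ring and brings in a hydrogen-bond donor and hydrogen-bond acceptors, yet the read-out does not move toward higher toxicity in this test, so this open-chain group is accepted here with no sign of added cytotoxicity. The value of compound 3 is a limit and not a number, so the step is only a floor, and the series now crowds against the top of the test: the limit of > 100000 nM in this assay, at which 2 of the 3 values shown sit.

Going by these compounds, how far compound 3 lies past that limit stays open, and with it the true size of the step and whether it would clear the usual scatter. Also open, on these data alone, is whether a dimethylamino group or a carboxylic acid at this carbonyl carbon would bring the number down in this assay, and what (tert-butoxycarbonyl)amino would do on the core of compound 2.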